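This account rests on a few compounds, and the source may have more. Where it says the series, first, only, none or still open, it means among the compounds named here.

Working notes on the series. For the measured compounds named here, in a functional assay on the whole organism with Mus musculus as the target (on this read-out lower numbers stand for an effect already at smaller amounts and higher numbers for an effect only at larger amounts of compound), compound 1 `C[C@@H](NCc1ccc(Cc2ccccc2)cc1)C(N)=O` gives 15.7 mg/kg and compound 2 `C[C@@H](NCc1ccc(CCc2ccccc2)cc1)C(N)=O` gives 40.3 mg/kg, so compound 2 holds the higher of the two numbers so far. Compound 3 `C[C@@H](NCc1ccc(COc2ccccc2)cc1)C(N)=O` has not been measured. It differs from compound 2 on a saturated chain carbon bound to an aromatic carbon, with phenoxy in place of benzyl on a saturated chain carbon bound to an aromatic carbon.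

Going by the values given here, only one measured step bears on this change. At the same place, a 2.6-fold higher number from compound 1 to compound 2 (0.41 log units; beyond the scatter), a modest move that came with benzyl replacing phenyl. Among the compounds with values here, it says how sensitive this place can be, but no measured compound carries phenoxy, so it gives no firm direction. A step no larger than that one is therefore expected in this assay, leaning slightly towards lower numbers and probably within the scatter. The expected change is a 1.3-fold lower number from compound 2 to compound 3 (0.13 log units; within the scatter). For compound 3 the estimated value is 30 mg/kg, with an expected range of 12 mg/kg to 70 mg/kg.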

Compound 3, dose for half-maximal effect: 40.3 mg/kg
The estimate for compound 3 lay 1.3-fold (0.13 log units) below the measured number; low and high end bracket the measured number.
By their numbers in this assay, from the lowest: compound 1; then compounds 2 and 3 (each within the scatter of the next).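

In this assay, phenoxy in place of benzyl on a saturated chain carbon bound to an aromatic carbon gives no change at the digits printed from compound 2 to compound 3 (within the scatter), so this place, which had responded to the earlier change, shows no readable response to this one, even though phenoxy carries one hydrogen-bond acceptor and benzyl none at the same count of heavy atoms. Phenoxy in place of phenyl at the same place gives a 2.6-fold higher number from compound 1 to compound 3 (0.41 log units; beyond the scatter), which shows that the earlier step was not unique to benzyl: two different groups now stand at the same distance from compound 1 and in the same direction. No measurement at hand accounts for either step, or for the lack of a readable difference between compound 2 and compound 3.

On these data alone, it remains open whether a longer chain such as phenylpropyl, or a phenylthio or anilino group at this place, would also stay within the scatter of compound 3 or move away from it. As far as these compounds go, it is equally open whether a carboxylic acid or an amine at this place would move the number in either direction.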